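The source may hold more compounds than are shown below. What is called first, only, known or untested is meant among the compounds shown, and "the series" means these compounds.

Measured so far, in an assay for binding affinity to Alpha-1B adrenergic receptor (Homo sapiens); on this read-out higher numbers stand for weaker inhibition and lower numbers for stronger inhibition:
compound 1 `CN1CCC[C@@H]1Cn1nc(Cc2ccc(F)cc2)c2ccccc2c1=O` gives 79.4 nM.
compound 2 `COc1ccc(Cc2nn(C[C@H]3CCCN3C)c(=O)c3ccccc23)cc1OC` gives > 1990 nM, a limit of the assay rather than a number.

Compound 2 thus stands at the limit of > 1990 nM in this assay, at which 1 of the 2 values shown sits, the weaker end of the two values shown. Compound 3 `COc1ccc(Cc2nn(C[C@H]3CCCN3C)c(=O)c3ccccc23)cc1` differs from compound 2 by hydrogen in place of methoxy on an aromatic carbon. Within the data shown here, no measured pair isolates such a change. The estimated step from compound 2 to compound 3 in this assay is an at least 2.4-fold lower number from compound 2 to compound 3 (0.39 log units; beyond the scatter), expected toward stronger binding and beyond the scatter. Compound 3 is expected in this assay at 800 nM, within 200 nM to 3000 nM.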

Compound 3, inhibition constant: 158 nM
Beside the measured number, compound 3's estimate is 5.1-fold (0.70 log units) above it, and the stated range ends above it.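

Hydrogen in place of methoxy on the aromatic carbon ortho to a methoxy group and meta to a large group gives an at least 12-fold lower number from compound 2 to compound 3 (1.10 log units; beyond the scatter) in this assay, so the series is sensitive to substitution at this one position. Compound 2 gives a limit of the assay, > 1990 nM, not a number. With a single group on the ring, methoxy in place of fluoro gives a 2.0-fold higher number from compound 1 to compound 3 (0.30 log units; within the scatter), so these two groups are not told apart.

Open, from the compounds shown here alone, is how a hydroxyl, an amine or an ethoxy group reads in place of the remaining methoxy in this assay.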